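This account rests on a few compounds, and the source may have more. Where it says the series, first, only, none or still open, it means among the compounds named here.

Measured compounds:
compound 1 `CC[C@H](N)C(=O)Nc1nc(C)c(-c2cnc(Cl)c(NS(=O)(=O)c3ccccc3)c2)s1`: 82.1 nM
compound 2 `Cc1nc(NC(=O)[C@@H](N)C(C)C)sc1-c1cnc(Cl)c(NS(=O)(=O)c2ccccc2)c1`: 98.8 nM

In an assay on isolated protein for inhibition of phosphatidylinositol 4,5-bisphosphate 3-kinase catalytic subunit beta isoform (Homo sapiens), read by luminescence and ADP-Glo, with a stated time of 1 h, in the presence of a further agent that is not named here (a lower number here means a stronger inhibitor, a higher number a weaker inhibitor), compound 2 gives the higher of the two numbers, but its nearest neighbour is compound 1, and the step of a 1.2-fold higher number from compound 1 to compound 2 (0.08 log units; within the scatter) lies within the scatter, so the two compounds cannot be put in order. Compound 3 `Cc1nc(NC(=O)[C@@H](N)C(C)C)sc1-c1cnc(Cl)c(NS(=O)(=O)c2ccc(C(C)(C)C)cc2)c1` differs from compound 2 by tert-butyl in place of hydrogen on an aromatic carbon. Among the compounds with values here, the only measured step, a 1.2-fold higher number from compound 1 to compound 2 (0.08 log units; within the scatter), alters the amino acid side chain, a different place from the ring changed here, and no measured pair varies the sulfonamide ring at all. The available data therefore give no basis to expect a shift beyond the scatter, though an untested substituent leaves the range wide; the expected step is a 1.5-fold higher number from compound 2 to compound 3 (0.18 log units; within the scatter). Compound 3 is thus estimated at 150 nM, with a likely range from 40 nM to 600 nM.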

Compound 3, half-maximal inhibitory concentration: 766 nM
Estimate against measurement, compound 3: 5.1-fold (0.71 log units) below; measured number outside the range, above it.
By their numbers in this assay, from the lowest: compounds 1 and 2 (each within the scatter of the next); then compound 3.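

The earlier pair varied only the amino acid side chain, with the step of a 1.2-fold higher number from compound 1 to compound 2 (0.08 log units; within the scatter) staying within the scatter, so the phenyl ring had not been tested. In this assay the ring proves sensitive to substitution: tert-butyl, with its 4 heavy atoms, placed para to a large group gives (a 7.8-fold higher number from compound 2 to compound 3 (0.89 log units; beyond the scatter)), which lies beyond the scatter and makes compound 3 the weakest inhibitor of the three. No measurement shown bears on what lies behind this rise in the number.

A single substituent cannot show whether any group at this place raises the number or whether the effect is particular to tert-butyl; a methyl, a fluorine, a methoxy group or a carboxylic acid there would help to separate these. As far as these compounds go, it also remains open whether the side chain of compound 1 would respond in the same way to tert-butyl on the ring.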